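Carboxy to ethoxycarbonyl on compound 3

This account rests on a few compounds, and the source may have more. Where it says the series, first, only, none or still open, it means among the compounds named here.

In a functional assay on the whole organism (strain Sprague-Dawley) for inhibition, with Rattus norvegicus as the target, with a stated time of 10 min (on this read-out lower numbers stand for an effect already at smaller amounts and higher numbers for an effect only at larger amounts of compound), compound 1 (`CCOC(=O)c1cnc(-c2ccccc2OCC)[nH]c1=O`) gives 2 mg/kg. Compound 2 (`CCOC(=O)c1cnc(-c2ccccc2)n(C)c1=O`) has only a limit, > 5 mg/kg. Compound 3 (`CCOc1ccccc1-c1ncc(C(=O)O)c(=O)n1C`) also has only a limit, > 50 mg/kg, so its place in the series carries no number.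

Compound 4 (`CCOC(=O)c1cnc(-c2ccccc2OCC)n(C)c1=O`) has ethyl in place of hydrogen on an oxygen next to a carbonyl group, carboxy to ethoxycarbonyl (ethyl in place of hydrogen on an oxygen next to a carbonyl group).

A large move towards smaller doses in this assay is expected, beyond the scatter: an at least 8.3-fold lower number from compound 3 to compound 4 (0.92 log units; beyond the scatter). The expectation rests on compound 1, which also carries ethoxycarbonyl and gives 2 mg/kg. For compound 4 the estimate is 6 mg/kg, with an expected range of 1.5 mg/kg to 25 mg/kg.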

Compound 4, dose for 50% inhibition: > 40 mg/kg
Compound 4: a limit, no number (the forecaster's own chance of this, stated with the estimate: 35%); middle value at least 6.6-fold (0.82 log units) from the limit.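

In this assay, going by these compounds alone, methyl in place of hydrogen on an aromatic nitrogen gives the first readable step, an at least 20-fold higher number from compound 1 to compound 4 (1.30 log units; beyond the scatter). Ethoxycarbonyl alone therefore does not secure a low dose: in this pair, the hydrogen on that nitrogen goes with the effect. The steps to compound 4 from compound 2 and compound 3 cannot be read, as both ends of each are limits.

Still open, on these data alone, is whether a longer chain, such as propyl, on that nitrogen behaves like methyl. Also open, as far as these compounds go, is how a carboxylic acid fares on the core of compound 1, with that hydrogen kept.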